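The source may hold more compounds than are shown below. What is called first, only, known or untested is meant among the compounds shown, and "the series" means these compounds.

Values in an ADME assay on Caco-2 cells (Homo sapiens) for permeability, read by LC-MS, in the apical to basolateral direction, with a stated time of 60 min, at pH 6.5 (on this read-out higher numbers stand for higher permeability and lower numbers for lower permeability), so far:
compound 1 `COC(C)(C)[C@@H](O)C(=O)N1C[C@H]2C[C@H]2[C@H]1C(=O)NCc1cc(Cl)ccc1-n1cnnn1` gives 3.5 10^-6 cm/s
compound 2 `CC(C)(C)[C@@H](O)C(=O)N1C[C@H]2C[C@H]2[C@H]1C(=O)NCc1cc(Cl)ccc1-n1cnnn1` gives 3.8 10^-6 cm/s
compound 3 `CC1(C[C@@H](O)C(=O)N2C[C@H]3C[C@H]3[C@H]2C(=O)NCc2cc(Cl)ccc2-n2cnnn2)CC1` gives 2.2 10^-6 cm/s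

Compound 3 cannot be separated from the other two measured compounds. The steps leading to it are a 1.6-fold lower number from compound 1 to compound 3 (0.20 log units; within the scatter) and a 1.7-fold lower number from compound 2 to compound 3 (0.24 log units; within the scatter) and neither leaves the scatter. The remaining step is a 1.1-fold higher number from compound 1 to compound 2 (0.04 log units; within the scatter) and it also stays within the scatter.

Compound 4 `O=C(NCc1cc(Cl)ccc1-n1cnnn1)[C@@H]1[C@@H]2C[C@@H]2CN1C(=O)[C@H](O)c1ccccc1F` is the next structure, and its difference is 2-fluorophenyl in place of (1-methylcyclopropyl)methyl on a saturated chain carbon bound to a carbonyl carbon and an oxygen on a saturated carbon with 2-fluorophenyl in place of (1-methylcyclopropyl)methyl on a saturated chain carbon bound to a carbonyl carbon and an oxygen on a saturated carbon. The two steps bearing most directly on this change are the ones already given into compound 3, since both swap the group at this same place. For the measured compounds named here, both are small, but no measured compound carries an aromatic ring at this place, so they are only a loose guide and the range is kept wide. In this assay the expected step is a 1.4-fold higher number from compound 3 to compound 4 (0.13 log units; within the scatter) and nothing beyond the scatter is expected. Compound 4 is expected at 3 10^-6 cm/s with an estimated range of 1.3 10^-6 cm/s to 6.5 10^-6 cm/s for now.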

Compound 4, apparent permeability: 2.3 10^-6 cm/s
Compound 4: the middle estimate sits 1.3-fold (0.12 log units) above what was measured; the measured number falls inside the stated range.
By their numbers in this assay, from the lowest: compounds 3, 4, 1 and 2 (each within the scatter of the next).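

In this assay, 2-fluorophenyl on a saturated chain carbon bound to a carbonyl carbon and an oxygen on a saturated carbon is the only aromatic ring at this place among the compounds shown, yet every step into compound 4 stays within the scatter: against (1-methylcyclopropyl)methyl (a 1.0-fold higher number from compound 3 to compound 4 (0.02 log units; within the scatter)), against tert-butyl (a 1.7-fold lower number from compound 2 to compound 4 (0.22 log units; within the scatter)) and against 1-methoxy-1-methylethyl (a 1.5-fold lower number from compound 1 to compound 4 (0.18 log units; within the scatter)). The read-out therefore does not separate the aromatic group from the three saturated groups at this place, and none of the four compounds goes against that reading. No measurement is available that would explain this flat result.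

Whether the fluorine matters stays open, since unsubstituted phenyl does not appear among the compounds shown, and the same goes for other placements of fluorine on the ring. It also remains unknown whether a group of a different kind at this place, such as an amine or a carboxylic acid, would move the number beyond the scatter, as none of the four groups shown does.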